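The source may report more compounds than this note shows. Statements on the series, on what has been measured and on what is new or still open speak of the compounds shown alone.

Three compounds sharing one core have been examined in an assay on a protein complex for inhibition of CDK8/Cyclin C (Homo sapiens), with a stated time of 1 h, tested at 10 uM; on this read-out lower numbers stand for less inhibition and higher numbers for more inhibition at the one concentration tested (going by the name of the read-out). Compound 1 `O=C(O)/C=C/c1ccncc1-c1ccc2cc[nH]c2c1` gives 103% in this assay. Compound 2 `NC(=O)/C=C/c1ccncc1-c1ccc2ccccc2c1` gives 102% in this assay. Compound 3 `CC(C)[C@@H](NC(=O)/C=C/c1ccncc1-c1ccc2ccccc2c1)C(=O)O` gives 77% in this assay, which places it lowest of the three numbers, with compound 2 nearest and compound 1 furthest, both beyond the scatter.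

Within the data shown here, only one step within the set bears on the question at hand: putting 1-carboxy-2-methylpropyl in place of hydrogen on an amide-type nitrogen changed this assay by a number 25 percentage points lower from compound 2 to compound 3 (beyond the scatter), a modest drop.

Compound 4 `COC1CN(C(=O)/C=C/c2ccncc2-c2ccc3ccccc3c2)C1` has not been measured. It differs from compound 3 in one place: 3-methoxyazetidin-1-yl in place of (1-carboxy-2-methylpropyl)amino on a carbonyl carbon. The change removes the group whose arrival in compound 3 went with the drop in this assay, and brings a smaller ring-bearing group in its place. Among the measured compounds shown here, no measured step shows what 3-methoxyazetidin-1-yl itself does on this carbonyl carbon, so the expectation rests on the single step observed.

Compound 4 is therefore expected to move back toward the values of compound 1 and compound 2, by a number 15 percentage points higher from compound 3 to compound 4 (beyond the scatter) in this assay. The estimate for compound 4 in this assay is 92%, within a range from 75% to 105%.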

Compound 4, a percentage reported as inhibition, at one concentration (the size of the read-out at that concentration, not a potency): 100%
Estimate against measurement, compound 4: 8 percentage points below; measured number inside the range.
By their numbers in this assay, from the lowest: compound 3; then compounds 4, 2 and 1 (each within the scatter of the next).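

In this assay, 3-methoxyazetidin-1-yl in place of (1-carboxy-2-methylpropyl)amino on the carbonyl carbon gives a number 23 percentage points higher from compound 3 to compound 4 (beyond the scatter) and so shows that the lower number of compound 3 does not extend to every larger group at this place. Set against the plain amino group, the same change gives a number 2 percentage points lower from compound 2 to compound 4 (within the scatter) and so shows that this carbonyl carbon can carry a four-membered ring with no hydrogen-bond donors and still read like the primary amide. Among the three groups shown on this carbonyl carbon, only (1-carboxy-2-methylpropyl)amino goes with a number beyond the scatter of the others, and that rests on compound 3 alone.

Still open, as far as these compounds go, is which part of that group goes with the lower number, the carboxylic acid or the branched chain, which a methyl ester or a primary alcohol in place of the acid could help to separate, while a single concentration leaves any difference in potency between compound 2 and compound 4 unresolved. No measurement at hand gives a reason for the lower number of compound 3.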